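From Chlorophenyl to Thiophenyl: Estimating Growth Inhibition

The source may report more compounds than this note shows. Statements on the series, on what has been measured and on what is new or still open speak of the compounds shown alone.

Of the compounds shown here, two sharing one core have so far been measured in a functional assay on NCI-H460 cells (Homo sapiens) for inhibition, read by sulforhodamine B assay, with a stated time of 48 h; on this read-out higher numbers stand for weaker inhibition of growth and lower numbers for stronger inhibition of growth. Compound 1 `CC1=CC[C@H](C(C)(C)NC(=S)N/N=C/c2ccccc2O)CC1` gives 8400 nM. Compound 2 `CC1=CC[C@H](C(C)(C)NC(=S)N/N=C/c2cccc(Cl)c2)CC1` gives 21400 nM, the higher of the two numbers, so of these two it inhibits growth less strongly. Within the data shown here, the one step recorded so far, a 2.5-fold higher number from compound 1 to compound 2 (0.41 log units; beyond the scatter), came with 3-chlorophenyl in place of 2-hydroxyphenyl on a carbon with a double bond to nitrogen.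

Compound 3 `CC1=CC[C@H](C(C)(C)NC(=S)N/N=C/c2cccs2)CC1` has not yet been measured in this assay. It differs from compound 2 in one place: thiophen-2-yl in place of 3-chlorophenyl on a carbon with a double bond to nitrogen. Among the measured compounds shown here, no measured step concerns this exchange; the only step in hand replaced a different group on the same carbon, and it was modest. There is therefore no basis for expecting a move in either direction beyond the scatter, and the number for compound 3 is expected to sit near that of compound 2. Compound 3 is estimated at 15000 nM, with a range from 5000 nM to 45000 nM. The step this implies, a 1.4-fold lower number from compound 2 to compound 3 (0.15 log units; within the scatter), is expected to be small.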

Compound 3, concentration for total growth inhibition: 20800 nM
Estimate against measurement, compound 3: 1.4-fold (0.14 log units) below, and the stated range covers the measured number.
By their numbers in this assay, from the lowest: compound 1; then compounds 3 and 2 (each within the scatter of the next).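

On the carbon with a double bond to nitrogen, thiophen-2-yl, a five-membered aromatic ring with one hetero atom, replaced 3-chlorophenyl, a six-membered aromatic ring of carbon only, and this assay gave a 1.0-fold lower number from compound 2 to compound 3 (0.01 log units; within the scatter) so this exchange of ring size and ring atoms left the number within the scatter. Seen from compound 1, thiophen-2-yl in place of 2-hydroxyphenyl gave a 2.5-fold higher number from compound 1 to compound 3 (0.39 log units; beyond the scatter) and 3-chlorophenyl gave a 2.5-fold higher number from compound 1 to compound 2 (0.41 log units; beyond the scatter) so two different replacements of 2-hydroxyphenyl now both give higher numbers, and among these three compounds only compound 1 stands apart. Nothing measured here offers an explanation for this picture.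

The three compounds cannot show whether the lower number of compound 1 belongs to the hydroxyl itself or to the hydroxyphenyl ring as a whole, which a methoxy group or an amine in place of that hydroxyl could help to separate. Going by these compounds, it also remains open whether any ring is needed on this carbon, or whether a longer alkyl chain or a carboxylic acid would give a similar number.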